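The source may hold more compounds than are shown below. What is called first, only, known or untested is meant among the compounds shown, and "the series" means these compounds.

For the measured compounds named here, compound 1 `CNCc1ccc(-n2c(SC(C)c3ccccc3)nc3c(cnn3C)c2=O)cc1` stands highest of the two numbers so far. In an assay on isolated protein for inhibition of retinal dehydrogenase 2 (Homo sapiens), tested at 5 uM (a higher number here means more inhibition at the concentration tested (going by the name of the read-out), a lower number less inhibition), compound 1 gives 70%. Compound 2 `CC(Oc1nc2c(cnn2C)c(=O)n1-c1ccccc1)c1ccccc1` shares no single-point relation with compound 1; in this assay compound 2 gives 42%, a number lower than that of compound 1 by more than the scatter. Compound 3 `CC(Sc1nc2c(cnn2C)c(=O)n1-c1ccc(CN)cc1)c1ccccc1` differs from compound 1 by hydrogen in place of methyl on an amine nitrogen. Going by the values given here, no measured pair shows this change, so the expected step from compound 1 to compound 3 is small, within the scatter, and its direction is taken as neutral: a number 5 percentage points lower from compound 1 to compound 3 (within the scatter) is estimated. For compound 3 in this assay the estimate is 65%, with a range from 45% to 85%.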

Compound 3, a percentage reported as inhibition, at one concentration (the size of the read-out at that concentration, not a potency): 64%
The estimate for compound 3 lay 1 percentage points above the measured number; measured number inside the range.
By their numbers in this assay, from the lowest: compound 2; then compounds 3 and 1 (each within the scatter of the next).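

In this assay, hydrogen in place of methyl on an amine nitrogen gives a number 6 percentage points lower from compound 1 to compound 3 (within the scatter), so at this position the methyl group can be lost without a step beyond the scatter. For the compounds shown here, this is the only one-place pair so far, and it covers one change on one core. Nothing measured here gives a reason for this result.

Still open, as far as these compounds go, is how the number responds to a larger group on this nitrogen, such as dimethylamino or a longer alkyl chain. Also open, from the compounds shown here alone, is whether a carboxylic acid in place of the aminomethyl group would hold it.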